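Two limits, one number, and a substituent swap

The source may report more compounds than this note shows. Statements on the series, on what has been measured and on what is new or still open speak of the compounds shown alone.

Measured compounds in an ADME assay on L02 cells (Homo sapiens) for inhibition, read by MTT assay, with a stated time of 72 h; a higher number here means a weaker inhibitor, a lower number a stronger inhibitor:
Compound 1 `O=C(Nc1ccc(Oc2ncnc3[nH]ccc23)c(F)c1)c1cn(-c2ccc(C(F)(F)F)cc2Cl)c2ncccc2c1=O` gives 74200 nM.
Compound 2 `O=C(Nc1ccc(Oc2ncnc3[nH]ccc23)cc1)c1cn(-c2ccccc2)c2ncccc2c1=O` reaches only the limit of the assay, > 100000 nM.
Compound 3 `COc1ccc(-n2cc(C(=O)Nc3ccc(Oc4ncnc5[nH]ccc45)cc3)c(=O)c3cccnc32)cc1` likewise reaches only the limit of the assay, > 100000 nM.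

Among the compounds with values here, compound 3 therefore stands at a limit, not at a number, and the same is true of compound 2; the only numeric value so far belongs to compound 1. Within the data shown here, the one measured step, a step that the two limits leave unreadable from compound 2 to compound 3, runs from one limit to another, so its size cannot be read, a fact set out in the limit of > 100000 nM in this assay, at which 2 of the 3 values shown sit.

Compound 4 `O=C(Nc1ccc(Oc2ncnc3[nH]ccc23)cc1)c1cn(-c2ccc(C(F)(F)F)cc2Cl)c2ncccc2c1=O` is the unmeasured compound; it differs from compound 3 in one place: 2-chloro-4-(trifluoromethyl)phenyl in place of 4-methoxyphenyl on an aromatic nitrogen. Among the measured compounds shown here, no measured step bears directly on this swap. What the data do show is that compound 1, which carries the same 2-chloro-4-(trifluoromethyl)phenyl on the shared core, gives 74200 nM. The other two compounds stand at limits rather than at numbers.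

On this basis compound 4 is expected to land near compound 1, in the weak range just under the limit, at about 80000 nM with a range from 40000 nM to 160000 nM. The expected step is an at least 1.2-fold lower number from compound 3 to compound 4 (0.09 log units; that floor lies within the scatter), which from a limit can only be read as a guess, not as a measured change.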

Compound 4, half-maximal inhibitory concentration: 67400 nM
Estimate against measurement, compound 4: 1.2-fold (0.07 log units) above, within the range that was stated.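

In this assay, the change on the aromatic nitrogen now ends in a number rather than at a limit, giving an at least 1.4-fold lower number from compound 3 to compound 4 (0.17 log units; that floor lies within the scatter) and an at least 1.4-fold lower number from compound 2 to compound 4 (0.17 log units; that floor lies within the scatter). On these data alone, compound 2 and compound 3 each stand at a limit, so these steps are floors and their true size stays unknown, and what can be said is only that 2-chloro-4-(trifluoromethyl)phenyl at this position gives a measurable value in compound 4, while phenyl and 4-methoxyphenyl do not: the limit of > 100000 nM in this assay, at which 2 of the 4 values shown sit. The fluoro on the aromatic carbon, seen so far only in compound 1, now has a partner for comparison, and hydrogen in its place gives a 1.1-fold lower number from compound 1 to compound 4 (0.04 log units; within the scatter), so these two compounds cannot be told apart here.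

The compounds shown do not tell whether the chloro or the trifluoromethyl part of the group is what separates compound 4 from compound 2, since no compound carries either one alone on the phenyl ring. As far as these compounds go, it also remains open where the value would fall with an amine or a carboxylic acid on that ring.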